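This account rests on a few compounds, and the source may have more. Where it says the series, first, only, none or still open, it means among the compounds named here.

Working notes on the series in an assay on cells for inhibition of histone deacetylase 11 (Homo sapiens), read by fluorescence, with stated times of 3 h and 30 min, tested at 2 uM, in the presence of a further agent that is not named here; on this read-out higher numbers stand for more inhibition at the one concentration tested (going by the name of the read-out) and lower numbers for less inhibition. Two measured compounds share the same core and differ in a single substituent. Compound 1, `Nc1ccccc1NC(=O)/C=C/c1cn([C@@H]2C[C@H](C(=O)O)N(CCCc3ccccc3)C2)nn1`, in this assay returns only a limit of the assay, < 10%, and not a number. Compound 2, `Nc1ccccc1NC(=O)/C=C/c1cn([C@H]2C[C@H](CO)N(CCCc3ccccc3)C2)nn1`, in this assay gives 16%. On the numbers shown compound 2 holds the only numeric value of the pair. The other entry sits at the limit of < 10% in this assay, at which 1 of the 2 values shown sits. Among the measured compounds shown here, no step between the two measured compounds is available, so their values cannot be compared beyond this.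

Compound 3, `Nc1ccccc1NC(=O)/C=C/c1cn([C@@H]2C[C@H](CO)N(CCCc3ccccc3)C2)nn1`, is the next member to be measured: the two compounds have the same atoms and bonds and differ only in configuration as drawn: 1 of 3 stereo elements differ; a stereocentre at a saturated ring carbon is drawn S in compound 2 and R in compound 3. For the step from compound 2 to compound 3 in this assay no movement beyond the usual scatter is expected in either direction, since a single numeric value and one limit give no basis for a shift of any size. Compound 3 is therefore expected to give about 13%, within 0% to 26%. The expected step is thus a number 3 percentage points lower from compound 2 to compound 3 (within the scatter), with a fair chance that compound 3 comes back as a limit only.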

Compound 3, a percentage reported as inhibition, at one concentration (the size of the read-out at that concentration, not a potency): 12%
Estimate against measurement, compound 3: 1 percentage points above; low and high end bracket the measured number.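

In this assay the configuration at this saturated ring carbon can now be read directly, and the result is a number 4 percentage points lower from compound 2 to compound 3 (within the scatter), so S and R at this stereocentre are not told apart at the one concentration tested; the reading is a clean one for that stereocentre alone, resting on this: the fact that compounds 2 and 3 differ only in the configuration as drawn

The second change, hydroxymethyl in place of carboxy on a saturated ring carbon, now also has a step, a number at least 2 percentage points higher from compound 1 to compound 3 (that floor lies within the scatter). Compound 1 remains a limit of the assay and not a number, so this step sets only a floor and gives no size for the change: the limit of < 10% in this assay, at which 1 of the 3 values shown sits.

Still open, going by these compounds, is how an amine or a methyl ester in place of the hydroxymethyl would read in this assay, and whether either configuration would separate from the other with such a group on that ring carbon. The compounds shown also leave open what a longer chain in place of the phenyl-bearing chain on the ring nitrogen would do, and a single-concentration read-out gives no potency for any member of the series.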